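Shared core series: hydroxy added on the ethylamino chain

The source may report more compounds than this note shows. Statements on the series, on what has been measured and on what is new or still open speak of the compounds shown alone.

compound 1 `COCCOc1nc(N)c2nc(N)n(Cc3ccccc3)c2n1` — > 10000 nM
compound 2 `CCNc1nc2c(N)nc(OCCOC)nc2n1Cc1ccccc1` — 4420 nM

In a functional assay on PBMC cells (Homo sapiens) for activation (on this read-out higher numbers stand for an effect only at larger amounts of compound and lower numbers for an effect already at smaller amounts), compound 1 sits at a limit of the assay, > 10000 nM. In this assay, going by the values given here, compound 2 gives 4420 nM, the only number among the values shown. The value of compound 1 is a limit. Among the compounds with values here, the one measured step is an at least 2.2-fold lower number from compound 1 to compound 2 (0.35 log units; beyond the scatter), and its size is a lower bound because compound 1 sits at the limit of > 10000 nM in this assay, at which 1 of the 2 values shown sits.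

Compound 3 `COCCOc1nc(N)c2nc(NCCO)n(Cc3ccccc3)c2n1` differs from compound 2 by hydroxy in place of hydrogen on a saturated chain carbon, two bonds along the chain from a nitrogen on an aromatic ring. Within the data shown here, no measured step concerns this change. The measured step of an at least 2.2-fold lower number from compound 1 to compound 2 (0.35 log units; beyond the scatter) alters the same nitrogen substituent but by adding carbon, not hydroxy, so it gives only weak guidance. The expected outcome in this assay is a step within the scatter, with a wide range either way. Compound 3 is expected to give 4000 nM (range 1200 nM to 13000 nM). From compound 2 this estimate implies a 1.1-fold lower number from compound 2 to compound 3 (0.04 log units; within the scatter).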

Compound 3, half-maximal effective concentration: 5330 nM
For compound 3 the middle estimate is 1.3-fold (0.12 log units) below the measured one; low and high end bracket the measured number.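

In this assay, hydroxy in place of hydrogen on a saturated chain carbon, two bonds along the chain from a nitrogen on an aromatic ring, gives a 1.2-fold higher number from compound 2 to compound 3 (0.08 log units; within the scatter), so ethylamino and (2-hydroxyethyl)amino cannot be told apart on this read-out. Against hydrogen on that nitrogen, 2-hydroxyethyl gives an at least 1.8-fold lower number from compound 1 to compound 3 (0.27 log units; that floor lies within the scatter), and this floor alone does not establish a gain. Compound 1 stands at a limit of the assay, so the true size of that step remains unresolved: the limit of > 10000 nM in this assay, at which 1 of the 3 values shown sits.

Going by these compounds, how an amine or a carboxylic acid in place of the hydroxy would read on this chain remains open. So does the effect of a longer chain, such as 3-hydroxypropyl, on the same nitrogen.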